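Restoring the Hydroxylated Bicyclic Amide: What Solubility to Expect

The source may hold more compounds than are shown below. What is called first, only, known or untested is meant among the compounds shown, and "the series" means these compounds.

Among the measured compounds shown here, compound 2 `CNC(=O)c1cc(C(=O)N[C@H]2C[C@@H]2C)cc2c1OC[C@@]2(C)c1ccccc1` is the only compound here with a plain number in a physicochemical assay for solubility; a lower number here means a less soluble compound, a higher number a more soluble compound: compound 2 gives 3 ug/mL. Compound 1 `CNC(=O)c1cc(C(=O)N[C@H]2[C@@H]3C[C@H](O)C[C@@H]32)cc2c1OC[C@@]2(C)c1ccccc1` carries a larger ring-fused group on the same amide-type nitrogen. In this assay compound 1 gives >= 151 ug/mL, which is a limit of the assay rather than a number. Compound 3 `CNC(=O)c1cc(C(=O)N[C@H]2[C@@H]3C[C@@H](O)C[C@@H]32)cc2c1OC[C@@]2(C)c1ccccc1` has not yet been measured; it differs from compound 2 in that (a group of 7 heavy atoms (6 carbon, 1 oxygen; one three-membered non-aromatic ring of carbon only, one five-membered non-aromatic ring of carbon only) in place of a group of 4 heavy atoms (4 carbon; one three-membered non-aromatic ring of carbon only), on an amide-type nitrogen). For the measured compounds named here, the one measured step that bears on this change runs the opposite way: an at least 50-fold lower number from compound 1 to compound 2 (1.70 log units; beyond the scatter). Going from compound 2 to compound 3 reverses that exchange, so a large rise in this assay is expected, and the measurement may well end again at the limit of >= 151 ug/mL in this assay, at which 1 of the 2 values shown sits. For compound 3 the estimate is 150 ug/mL, within the range 40 ug/mL to 400 ug/mL, meaning an expected step of a 50-fold higher number from compound 2 to compound 3 (1.70 log units; beyond the scatter).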

Compound 3, solubility: >= 209 ug/mL
Compound 3: only a limit was reported; the forecaster's own chance of this, stated with the estimate: 65%; middle value at least 1.3-fold (0.14 log units) away from the limit.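

In this assay, the large rise holds with the stereocentre at the saturated ring carbon drawn the other way: exchanging 2-methylcyclopropyl for the larger ring-fused group on the amide-type nitrogen gives an at least 69-fold higher number from compound 2 to compound 3 (1.84 log units; beyond the scatter). Compound 3 ends at a limit of the assay, not a number: the limit of >= 209 ug/mL in this assay, at which 1 of the 3 values shown sits. Compound 1 and compound 3 both end at limits, so the step between them cannot be read, and any effect of the drawn configuration stays hidden: the fact that compounds 1 and 3 differ only in the configuration as drawn

Going by these compounds, how far each of these two compounds lies past its limit remains open, and with it whether the configuration matters at all in this assay. Also open, on these data alone, is whether the full ring-fused group is needed, or whether a simpler group on the same nitrogen, such as a 2-hydroxyethyl chain, would give a similar reading.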